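The compounds below may be only part of what the source reports. "The series", "measured", "known", "first", "only" and "open" are said of these compounds alone.

Working notes on the series. Of the compounds shown here, three have been read so far in an ADME assay on L6 cells (Rattus norvegicus) for cytotoxicity; a higher number here means a weaker inhibitor, a lower number a stronger inhibitor. Compound 1 `O=C(NCCCn1ccnc1[N+](=O)[O-])c1ccc(OC(F)(F)F)cc1` gives 274000 nM. Compound 2 `O=C(NCCn1cnc([N+](=O)[O-])n1)c1ccc(C(F)(F)F)cc1` gives only a limit of the assay, > 273000 nM. Compound 3 `O=C(NCCCCn1cnc([N+](=O)[O-])n1)c1ccc(C(F)(F)F)cc1` gives 104000 nM, the lower of the two actual numbers, and its gap to compound 1 lies beyond the scatter.

Compound 4 `O=C(NCCCCn1cnc([N+](=O)[O-])n1)c1ccc(OC(F)(F)F)cc1` is the next to be read. It keeps the chain of compound 3 and has trifluoromethoxy in place of trifluoromethyl on an aromatic carbon. Going by the values given here, no measured pair isolates this exchange, so the data give no direct size for it. In this assay, the expectation is therefore no change beyond the scatter, with a slight lean toward a lower number. The expected step is a 1.2-fold lower number from compound 3 to compound 4 (0.09 log units; within the scatter). For compound 4 the estimated value is 85000 nM, with an expected range from 40000 nM to 180000 nM.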

Compound 4, half-maximal inhibitory concentration: > 268000 nM
Compound 4 gave a limit, no number; the forecaster's own chance of this, stated with the estimate: 5%; middle value at least 3.1-fold (0.49 log units) from the limit.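

In this assay, trifluoromethoxy in place of trifluoromethyl on an aromatic carbon, para to a large group, gives an at least 2.5-fold higher number from compound 3 to compound 4 (0.41 log units; beyond the scatter). Going by these compounds alone, this pair is the first to isolate the exchange, and it shows that the position is not indifferent to it, with the change running toward a higher number. Compound 4 reads only as a limit of the assay, so the step has a floor but no full size: the limit of > 268000 nM in this assay, at which 1 of the 4 values shown sits.

Within the data shown here, whether the exchange acts in the same way on a shorter chain or on the core of compound 1 stays open, as no other pair isolates it. The compounds shown also leave open how a nitrile or a chlorine at this position, or a longer chain, would read in this assay.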